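Swapping the aryl group on a tethered oxygen

The source may hold more compounds than are shown below. What is called first, only, known or untested is meant among the compounds shown, and "the series" means these compounds.

Three compounds share one core and differ only in the aromatic group carried on the chain oxygen. Compound 1 `NC1=NC2(CCOCC2)N(OCCCOc2ccc(Cl)c(Cl)c2)C(N)=N1` bears a dichlorinated ring, and in a functional assay on HepG2 cells (Homo sapiens) for antiproliferative activity, read by MTT assay, with a stated time of 72 h (on this read-out higher numbers stand for weaker inhibition and lower numbers for stronger inhibition), compound 1 gives 380 nM. Compound 2 `Cc1ccc(OCCCON2C(N)=NC(N)=NC23CCOCC3)cc1` carries a methylated ring instead, but in this assay compound 2 gives "not determined" (no result reported), so it stands without a number. Compound 3 `NC1=NC2(CCOCC2)N(OCCCOc2ccccc2Br)C(N)=N1` is the next step: 2-bromophenyl in place of 4-methylphenyl on an oxygen on a saturated carbon. Within the data shown here, with no measured pair sharing this exact change, the size and direction of the step cannot be read from the data and no expectation beyond the scatter can be grounded. The only anchor is a halogenated relative, and compound 3 is expected to land in the same region because compound 1 gives 380 nM. Compound 3 is therefore estimated at 600 nM, within 200 nM to 2500 nM.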

Compound 3, half-maximal inhibitory concentration: 860 nM
Beside the measured number, compound 3's estimate is 1.4-fold (0.16 log units) below it; measured number inside the range.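

In this assay, the aromatic group on the chain oxygen is not a silent part of the molecule: 2-bromophenyl in place of 3,4-dichlorophenyl gives a 2.3-fold higher number from compound 1 to compound 3 (0.35 log units; beyond the scatter), a modest change but one beyond the scatter. Among these compounds, with no number for compound 2, the step to compound 3 cannot be read, so this pair of halogenated rings is the only comparison at this position. Nothing at hand explains why the two halogenated compounds differ on this read-out.

Compound 1 and compound 3 differ in both the kind and the placing of their halogens, and the compounds shown do not separate these two changes. On these data alone, how a ring carrying an amine or a carboxylic acid, or a longer chain to the ring, would behave here remains open.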